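Ester in place of ether on the phenolic oxygen

The source may hold more compounds than are shown below. What is called first, only, known or untested is meant among the compounds shown, and "the series" means these compounds.

Compound 1 `C#CCOc1cc(/C=C/C(=O)c2ccc(OC)c3c2OC(C)(C)C=C3)ccc1OC` is the starting point. In a functional assay on A-375 cells (Homo sapiens) for cytotoxicity, read by MTT assay (on this read-out lower numbers stand for stronger inhibition and higher numbers for weaker inhibition), compound 1 gives > 10000 nM, a limit of the assay and not a number. Compound 1 therefore stands at the limit of > 10000 nM in this assay, at which 2 of the 3 values shown sit. Compound 2 `C=CCOc1cc(/C=C/C(=O)c2ccc(OC)c3c2OC(C)(C)C=C3)ccc1OC` carries vinyl in place of ethynyl on the same side chain; in this assay compound 2 gives > 10000 nM, again a limit. The step that the two limits leave unreadable from compound 1 to compound 2 is all that can be said of that pair. Compound 3 `COc1ccc(/C=C/C(=O)c2ccc(OC)c3c2OC(C)(C)C=C3)cc1OC(=O)C1CC1` bears cyclopropylcarbonyl on the oxygen on the aromatic ring, and in this assay compound 3 gives 380 nM. This yields an at least 26-fold lower number from compound 1 to compound 3 (1.42 log units; beyond the scatter) and an at least 26-fold lower number from compound 2 to compound 3 (1.42 log units; beyond the scatter).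

Compound 4 `COc1ccc(/C=C/C(=O)Oc2cc(/C=C/C(=O)c3ccc(OC)c4c3OC(C)(C)C=C4)ccc2OC)cc1` differs from compound 1 by (2-(4-methoxyphenyl)ethenyl)carbonyl in place of propargyl on an oxygen on an aromatic ring. As with compound 3, the ether on the oxygen on the aromatic ring becomes an ester, so the step of an at least 26-fold lower number from compound 1 to compound 3 (1.42 log units; beyond the scatter) is the one that bears on it, and a large fall in the number is expected. Compound 4 is expected to give 500 nM, with a range of 120 nM to 3000 nM. The expected step is an at least 20-fold lower number from compound 1 to compound 4 (1.30 log units; beyond the scatter). Within the data shown here, only one ester precedent exists, so the range is kept wide.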

Compound 4, half-maximal inhibitory concentration: 2630 nM
Compound 4: the middle estimate sits 5.3-fold (0.72 log units) below what was measured, within the range that was stated.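

A second ester on the oxygen on an aromatic ring also gives a lower number than the ethers in this assay, with an at least 3.8-fold lower number from compound 1 to compound 4 (0.58 log units; beyond the scatter) and an at least 3.8-fold lower number from compound 2 to compound 4 (0.58 log units; beyond the scatter), so the fall seen with compound 3 is not confined to cyclopropylcarbonyl. Both of these steps start from a limit of the assay and not from a number: the limit of > 10000 nM in this assay, at which 2 of the 4 values shown sit.

Placing 2-(4-methoxyphenyl)ethenyl in place of cyclopropyl on a carbonyl carbon gives a 6.9-fold higher number from compound 3 to compound 4 (0.84 log units; beyond the scatter), so the group carried by the ester carbonyl also shifts the number, and this is the only new step read between two actual numbers.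

Two esters do not settle which feature of that group sets the number. Going by these compounds, how a carbamate or a longer saturated acyl chain on the same oxygen would read remains open.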